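Swapping a Five-Membered Ring for a Pyridine on the Core

This account rests on a few compounds, and the source may have more. Where it says the series, first, only, none or still open, it means among the compounds named here.

Three compounds have been measured in an assay on isolated protein for inhibition of DNA topoisomerase 1 (Homo sapiens), with a stated time of 30 min, tested at 100 uM; on this read-out lower numbers stand for a weaker effect and higher numbers for a stronger effect at the one concentration tested:

- compound 1, `Oc1ccc(-c2cc(-c3cccs3)nc(-c3ccccc3Cl)c2)cc1`, gives 2.2%
- compound 2, `Oc1ccc(-c2cc(-c3ccc(Cl)cc3)nc(-c3cccs3)c2)cc1`, gives 38.8%
- compound 3, `Oc1cccc(-c2cc(-c3cccs3)nc(-c3ccccc3Cl)c2)c1`, gives 2.7%

Compound 1 stands lowest of the three numbers, though compound 3 sits within the scatter of it, so no order between those two can be claimed. Compound 2 is the only one clearly apart: the step of a number 36.6 percentage points higher from compound 1 to compound 2 (beyond the scatter) is large and beyond the scatter, whereas the step of a number 0.5 percentage points higher from compound 1 to compound 3 (within the scatter) stays within it.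

Compound 4, `Oc1ccc(-c2cc(-c3cccnc3)nc(-c3ccccc3Cl)c2)cc1`, differs from compound 1 in one place: pyridin-3-yl in place of thiophen-2-yl on an aromatic carbon. Neither measured step touches this position. The step from compound 1 to compound 2 moves the chlorine on the chlorophenyl group, and the step from compound 1 to compound 3 moves the hydroxyl on the hydroxyphenyl group; both leave the thiophen-2-yl group untouched. There is therefore no direct guide for replacing thiophen-2-yl with pyridin-3-yl in this assay.

With the shared core otherwise unchanged, the expected step of a number 3.8 percentage points higher from compound 1 to compound 4 (within the scatter) is none beyond the scatter. Compound 4 is thus estimated at 6%, within a range from 0% to 25%. The range is wide; nothing measured bears on this change.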

Compound 4, a percentage reported as inhibition, at one concentration (the size of the read-out at that concentration, not a potency): 0.9%
Beside the measured number, compound 4's estimate is 5.1 percentage points above it; measured number inside the range.
By their numbers in this assay, from the lowest: compounds 4, 1 and 3 (each within the scatter of the next); then compound 2.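

Putting pyridin-3-yl in place of thiophen-2-yl, at the position next to the ring nitrogen, gives a number 1.3 percentage points lower from compound 1 to compound 4 (within the scatter), so in this assay this position accepts a six-membered aromatic ring with nitrogen and a five-membered aromatic ring with sulfur without a change that can be told from the scatter. This is a limited finding, since compound 1 already gives only 2.2%, which leaves very little room for any further fall to show, so the result can reveal a gain at this position but hardly a loss. Nothing available here explains the result or says how either ring acts at this position.

The compounds shown leave open whether the same exchange would also make no clear difference on a compound with a much larger read-out, such as compound 2 at 38.8%, where a loss would have room to appear. They also leave open how this position would respond to a group of a different kind, such as an amine, a carboxylic acid or a longer chain, in place of an aromatic ring.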